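Methyl in Place of Hydrogen on Compound 1

The source may report more compounds than this note shows. Statements on the series, on what has been measured and on what is new or still open speak of the compounds shown alone.

Among the measured compounds shown here, compound 1 `COC(=O)[C@@]1(C)CCC=C2[C@@H]1CC[C@@H](C)[C@]2(C)Cc1c[nH]c2ccccc12` gives 4500 nM in a functional assay on HBL-100 cells (Homo sapiens) for inhibition, read by sulforhodamine B assay, with a stated time of 48 h (a higher number here means a weaker inhibitor of growth, a lower number a stronger inhibitor of growth), one of only two numbers measured. Compound 2 `COC(=O)[C@@]1(C)CCC=C2[C@@H]1CC[C@@H](C)[C@]2(C)Cc1c[nH]c2ccc(F)cc12` gives 4800 nM in this assay, and the step of a 1.1-fold higher number from compound 1 to compound 2 (0.03 log units; within the scatter) sits within the scatter. Compound 3 `COC(=O)[C@@]1(C)CCC=C2[C@@H]1CC[C@@H](C)[C@]2(C)Cc1c(C)[nH]c2ccccc12` differs from compound 1 by methyl in place of hydrogen on an aromatic carbon. For the measured compounds named here, the single measured step concerns a different group at a different place, so it bears only loosely on this change and was itself within the scatter. No step beyond the scatter is therefore expected in this assay, an expectation that amounts to no change at the digits printed from compound 1 to compound 3 (within the scatter). Compound 3 is estimated at 4500 nM, expected to fall between 2000 nM and 10000 nM.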

Compound 3, concentration for 50% growth inhibition: 14000 nM
Estimate against measurement, compound 3: 3.1-fold (0.49 log units) below; measured number above the stated range.
By their numbers in this assay, from the lowest: compounds 1 and 2 (each within the scatter of the next); then compound 3.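

Methyl in place of hydrogen on this aromatic carbon gives a 3.1-fold higher number from compound 1 to compound 3 (0.49 log units; beyond the scatter) in this assay. Among the compounds shown here, this is the first step beyond the scatter, and it runs toward weaker inhibition of growth, whereas the fluoro step a 1.1-fold higher number from compound 1 to compound 2 (0.03 log units; within the scatter) stayed within it. With a different group at a different place in each step, the two cannot separate the effect of group from that of position, and nothing available explains the rise.

The compounds shown leave open whether ethyl, a longer chain or an amine on this same carbon would raise the number further. They also leave open what methyl would do on the carbon bearing fluoro in compound 2.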